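A few compounds are considered here, and "the series" means these few. Any claim that something is new, unique, unknown or untested is made for them only; others in the source may bear on it.

Working notes on the series. In a functional assay on HepG2 cells (Homo sapiens) for antiproliferative activity, read by MTT assay, with a stated time of 48 h (a higher number here means a weaker inhibitor, a lower number a stronger inhibitor), compound 1, `N#CC1=C(N)Oc2c(c3nc4ccccc4nc3c3ccccc23)C12C(=O)N(Cc1cnnn1-c1ccc(F)cc1)c1ccccc12`, gives only the assay limit > 50000 nM. Compound 2, `COc1ccc(-n2nncc2CN2C(=O)C3(C(C#N)=C(N)Oc4c3c3nc5ccccc5nc3c3ccccc43)c3ccccc32)cc1`, likewise gives only the limit > 50000 nM in this assay. Going by the values given here, the single measured step, a step that the two limits leave unreadable from compound 1 to compound 2, is thus unreadable, since both ends sit at the limit of > 50000 nM in this assay, at which 2 of the 2 values shown sit. Compound 3, `Cc1cc(C)cc(-n2nncc2CN2C(=O)C3(C(C#N)=C(N)Oc4c3c3nc5ccccc5nc3c3ccccc43)c3ccccc32)c1`, differs from compound 2 by 3,5-dimethylphenyl in place of 4-methoxyphenyl on an aromatic nitrogen. Among the compounds with values here, no measured step bears on this change; the only evidence is the limit of > 50000 nM in this assay, at which 2 of the 2 values shown sit, so no step beyond the scatter can be foreseen. The step is expected to be a number no higher from compound 2 to compound 3 (the limit leaves the size open), most likely again a limit. Compound 3 is estimated at 50000 nM, with a range from 20000 nM to 100000 nM.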

Compound 3, half-maximal inhibitory concentration: > 50000 nM
Compound 3: no number, only a limit; the forecaster's own chance of this, stated with the estimate: 80%; the middle value lies on the limit itself.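

Going by these compounds alone, compound 3 also gives only a limit, > 50000 nM in this assay, so no step from compound 1 or compound 2 to compound 3 can be read. The compounds shown leave open whether the 4-fluorophenyl, 4-methoxyphenyl and 3,5-dimethylphenyl groups differ at all in this assay.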